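A few compounds are considered here, and "the series" means these few. Any claim that something is new, unique, unknown or untested is made for them only; others in the source may bear on it.

Among the measured compounds shown here, compound 2 `N#Cc1c(Nc2ccccc2F)nc(SCc2cn(Cc3ccccc3Cl)nn2)nc1-c1ccccc1` gives 7580 nM in a functional assay on MGC-803 cells (Homo sapiens) for inhibition, read by MTT assay, with a stated time of 72 h (on this read-out lower numbers stand for stronger inhibition and higher numbers for weaker inhibition), the lowest of the two numbers so far. Compound 1 `N#Cc1c(Nc2cccc(Cl)c2)nc(SCc2cn(Cc3ccccc3Cl)nn2)nc1-c1ccccc1` gives 15800 nM in this assay, and the change to it from 3-chlorophenyl to 2-fluorophenyl on the nitrogen is a 2.1-fold lower number from compound 1 to compound 2 (0.32 log units; beyond the scatter). Compound 3 `N#Cc1c(Nc2ccccc2)nc(SCc2cn(Cc3ccccc3Cl)nn2)nc1-c1ccccc1` differs from compound 2 by hydrogen in place of fluoro on an aromatic carbon, on the aromatic carbon ortho to a large group. For the measured compounds named here, no measured step removes a halogen from this ring; the one step swaps both halogen and its place and bears only loosely. For compound 3 a step within the scatter is expected, a 1.3-fold higher number from compound 2 to compound 3 (0.10 log units; within the scatter). For compound 3 the estimate in this assay is 9500 nM, range 4000 nM to 25000 nM.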

Compound 3, half-maximal inhibitory concentration: > 64000 nM
Compound 3 gave a limit, no number (the forecaster's own chance of this, stated with the estimate: 5%); middle value at least 6.7-fold (0.82 log units) from the limit.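

Compound 3 stands only as a limit of the assay, not as a number: the limit of > 64000 nM in this assay, at which 1 of the 3 values shown sits. The earlier pair showed only one halogen swapped for another; here, hydrogen in place of fluoro gives an at least 8.4-fold higher number from compound 2 to compound 3 (0.92 log units; beyond the scatter), and hydrogen in place of chloro gives an at least 4.0-fold higher number from compound 1 to compound 3 (0.60 log units; beyond the scatter). Among these three compounds, only those with a halogen on this ring give a measured number.

Going by these compounds, whether a methyl or methoxy group on the same aromatic carbon would serve as fluoro does remains open. On these data alone, the full size of both steps also remains open.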